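The source may hold more compounds than are shown below. What is called first, only, known or untested is meant among the compounds shown, and "the series" means these compounds.

Measured in an ADME assay on microsomes from liver (Homo sapiens) for metabolic stability, read by LC-MS, with a stated time of 30 min, tested at 1 uM; on this read-out higher numbers stand for a more stable compound and lower numbers for a less stable compound:
- compound 1 `O=C(NCc1ccc(S(=O)(=O)c2ccccc2)cc1)c1ccc2nccn2c1`: 77%
- compound 2 `O=C(NCc1ccc(S(=O)(=O)N2CCCCC2)cc1)c1ccn2cncc2c1`: 54%
- compound 3 `O=C(NCc1ccc(S(=O)(=O)c2cccc(C(F)(F)F)c2)cc1)c1ccc2nccn2c1`: 26%

Compound 1, at 77%, holds the highest of the three numbers, and the other two compounds both lie beyond the scatter from it.

Compound 4 `O=C(NCc1ccc(S(=O)(=O)c2ccccc2)cc1)c1cnc2nccn2c1` departs from compound 1 in one place: a group of 9 heavy atoms (6 carbon, 3 nitrogen; one five-membered aromatic ring with 2 hetero atoms, one six-membered aromatic ring with 2 hetero atoms) in place of a group of 9 heavy atoms (7 carbon, 2 nitrogen; one five-membered aromatic ring with 2 hetero atoms, one six-membered aromatic ring with 1 hetero atom), on a carbonyl carbon.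

Among the measured compounds shown here, only one measured step changes a single place, and it is large: a number 51 percentage points lower from compound 1 to compound 3 (beyond the scatter). That step puts trifluoromethyl in place of hydrogen on an aromatic carbon and leaves the group on the carbonyl carbon untouched, so it gives no measure of the present change. Compound 2 differs from compound 1 in more than one place, so it offers no clean comparison either. For the measured compounds named here, with no measured step at this place, no shift beyond the scatter is expected in this assay, though the uncertainty is wide. The expected step is a number 2 percentage points lower from compound 1 to compound 4 (within the scatter). For compound 4 the estimated value is 75%, with an expected range from 52% to 93%.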

Compound 4, percent of the compound remaining: 60%
Beside the measured number, compound 4's estimate is 15 percentage points above it, and the stated range covers the measured number.
By their numbers in this assay, from the lowest: compound 3; then compounds 2 and 4 (each within the scatter of the next); then compound 1.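

The group on the carbonyl carbon proved to be a place that this assay responds to: exchanging one carbon of the six-membered aromatic ring for nitrogen gives a number 17 percentage points lower from compound 1 to compound 4 (beyond the scatter). Among the compounds shown here, the earlier single-place step changed only the other end of the molecule, so this is the first clean reading at this position, and it shows that even a change this small, which keeps the heavy-atom count and raises the hydrogen-bond acceptors from 2 to 3, moves the number beyond the scatter. No measurement shown here explains the drop.

As far as these compounds go, with a single replacement at this place, it remains open whether other groups on the carbonyl carbon, such as a plain phenyl ring or a methoxy-bearing version of the two-ring group, would hold the number of compound 1 or lose more. From the compounds shown here alone, it is also open whether the same exchange would shift the number by a similar amount in the trifluoromethyl series of compound 3.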